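The compounds below may be only part of what the source reports. "The series", "measured", "known", "first", "only" and "open" are said of these compounds alone.

In an ADME assay on microsomes from liver (Homo sapiens) for metabolic stability, read by LC-MS, using NADPH, with stated times of 5 min and 30 min, tested at 1 uM (on this read-out higher numbers stand for fast clearance and lower numbers for slow clearance), compound 1, whose structure is `O=C1CCCN1c1cnc(NCc2c(F)ccc3c2CCO3)n2cnnc12`, gives a result reported only as a limit of the assay, < 3 mL.min-1.g-1, rather than as a number. From the compounds shown here alone, compound 1 thus stands at the limit of < 3 mL.min-1.g-1 in this assay, at which 1 of the 2 values shown sits, the floor of what this assay resolves, so how far its true clearance lies under that floor is unknown. The second measured compound, compound 2 with structure `Cc1nc(CN(C)C)ccc1-c1cnc(NCc2c(F)ccc3c2CCO3)c2cn[nH]c(=O)c12`, belongs to a different core and is not a single-change partner of compound 1; in this assay compound 2 gives 13 mL.min-1.g-1.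

Compound 3, with structure `CN(c1cccnc1)c1cnc(NCc2c(F)ccc3c2CCO3)n2cnnc12`, is the next compound to be measured. It differs from compound 1 in a single place: methyl(pyridin-3-yl)amino in place of 2-oxopyrrolidin-1-yl on an aromatic carbon. No change of this kind has been measured between two compounds here, so its size cannot be read from the data.

Given only a limit for compound 1, the expected step from compound 1 to compound 3 is an increase, of about an at least 2.6-fold higher number from compound 1 to compound 3 (0.42 log units; beyond the scatter), though the start point itself is uncertain. For compound 3 the estimated value is 8 mL.min-1.g-1, with a likely range from 3 mL.min-1.g-1 to 25 mL.min-1.g-1.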

Compound 3, intrinsic clearance in microsomes: 80 mL.min-1.g-1
Estimate against measurement, compound 3: 10-fold (1.00 log units) below, outside the stated range (above it).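

In this assay, the aromatic carbon that carries these groups turns out to matter a great deal: methyl(pyridin-3-yl)amino in place of 2-oxopyrrolidin-1-yl gives an at least 26-fold higher number from compound 1 to compound 3 (1.42 log units; beyond the scatter). Going by these compounds alone, the earlier compounds offered no single-change pair, so this is the first direct evidence that swapping the group at this place on the shared core can move clearance, and the move is large, with compound 3 at 80 mL.min-1.g-1. The printed step is only a minimum, as the result for compound 1 is a limit of the assay and not a number: the limit of < 3 mL.min-1.g-1 in this assay, at which 1 of the 3 values shown sits.

This single change replaces a whole group, so the result cannot show which part of methyl(pyridin-3-yl)amino goes with the higher clearance: the methyl, the pyridine ring or the amine nitrogen that joins them to the core. A phenyl ring in place of the pyridine, or a morpholine on the same carbon, would help to separate these parts, and whether the same step would appear on another core remains an open question.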